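Swapping an Aryl for an Ester in a Sulfonamide Series

This account rests on a few compounds, and the source may have more. Where it says the series, first, only, none or still open, it means among the compounds named here.

Measured so far:
compound 1 `Cc1ccc(-c2ccccc2S(=O)(=O)N2CCC(N3CCC(C)CC3)CC2)cc1` gives > 5000 nM
compound 2 `CC1CCN(C2CCN(S(=O)(=O)c3ccc(-c4ccccc4F)cc3)CC2)CC1` gives > 5000 nM
compound 3 `CC1CCN(C2CCN(S(=O)(=O)c3ccc(Cl)c(Cl)c3)CC2)CC1` gives > 5000 nM

Three sulfonamides with a shared core were tested in an ADME assay on HCT-116 cells (Homo sapiens) for cytotoxicity, read by CellTiter-Glo, with a stated time of 72 h; on this read-out higher numbers stand for weaker inhibition and lower numbers for stronger inhibition. For compound 1 the result is only a limit of the assay, > 5000 nM. Compound 2 likewise returns only a limit, > 5000 nM. Compound 3 also stops at a limit, > 5000 nM. Within the data shown here, compound 2 therefore stands where the whole set stands, because the limit of > 5000 nM in this assay, at which 3 of the 3 values shown sit: no compound has a real number.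

Compound 4 `COC(=O)c1ccc(S(=O)(=O)N2CCC(N3CCC(C)CC3)CC2)cc1` differs from compound 2 in one place: methoxycarbonyl in place of 2-fluorophenyl on an aromatic carbon. Among the measured compounds shown here, no pair of measured compounds differs in a single place, so no measured step guides this change. The step this estimate means, a step that the limit leaves unreadable from compound 2 to compound 4, is expected to be none beyond the scatter. Compound 4 is expected to give about 9000 nM in this assay, between 3000 nM and 30000 nM.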

Compound 4, half-maximal inhibitory concentration: > 5000 nM
Compound 4 ended at the assay's limit (the forecaster's own chance of this, stated with the estimate: 85%); the middle value does not contradict the limit.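

No step can be read from compound 2 to compound 4, since both stop at a limit in this assay: the limit of > 5000 nM in this assay, at which 4 of the 4 values shown sit.

The compounds shown leave open how strongly any of them acts in this assay, and whether methoxycarbonyl and 2-fluorophenyl differ at all.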